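A few compounds are considered here, and "the series" means these few. Any claim that something is new, unique, unknown or untested is made for them only; others in the source may bear on it.

In a functional assay on HT cells (Homo sapiens) for antiproliferative activity, read by fluorescence, with a stated time of 72 h (on this read-out higher numbers stand for weaker inhibition of growth and lower numbers for stronger inhibition of growth), the compounds differ only in the substituent on sulfur, on a shared core. Compound 1 (`CC(C)c1n[nH]c2c(NCc3ccc(-c4ccccn4)cc3)nc(SCCO)nc12`) gives 48 nM, compound 2 (`CC(C)c1n[nH]c2c(NCc3ccc(-c4ccccn4)cc3)nc(SC(CO)C(C)C)nc12`) gives 980 nM, and compound 3 (`CC(C)c1n[nH]c2c(NCc3ccc(-c4ccccn4)cc3)nc(SCCNC(N)=O)nc12`) gives 240 nM. Compound 3 holds the middle place of the three numbers, and the gap on its weaker side is a 4.1-fold lower number from compound 2 to compound 3 (0.61 log units; beyond the scatter).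

Compound 4 (`CC(C)c1n[nH]c2c(NCc3ccc(-c4ccccn4)cc3)nc(SCC(N)=O)nc12`) carries carbamoyl in place of ureidomethyl on a saturated chain carbon bound to a sulfur, which also reads as 2-ureidoethyl to carbamoylmethyl: carbamoyl in place of ureidomethyl on a saturated chain carbon bound to a sulfur.

Going by the values given here, no measured step makes this exact change. The nearest in kind is a 5.0-fold higher number from compound 1 to compound 3 (0.70 log units; beyond the scatter), a modest step that alters the end of the same chain and shows what compound 1 and compound 3 span in this assay. The large 20-fold higher number from compound 1 to compound 2 (1.31 log units; beyond the scatter) adds an isopropyl, which compound 4 does not carry, so it bears little on this change. A step no larger than modest is therefore expected, most likely none beyond the scatter, with a slight lean toward compound 1. The estimated step is a 1.6-fold lower number from compound 3 to compound 4 (0.20 log units; within the scatter). For compound 4 the expected value is 150 nM, with an estimated range of 50 nM to 450 nM.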

Compound 4, concentration for 50% growth inhibition: 192 nM
Beside the measured number, compound 4's estimate is 1.3-fold (0.11 log units) below it; the range from low to high includes it.
By their numbers in this assay, from the lowest: compound 1; then compounds 4 and 3 (each within the scatter of the next); then compound 2.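

In this assay, carbamoyl in place of ureidomethyl on a saturated chain carbon bound to a sulfur gives a 1.3-fold lower number from compound 3 to compound 4 (0.10 log units; within the scatter), so the difference in heavy atoms and hydrogen-bond donors between these two groups leaves no readable mark at this position. Carbamoyl in place of hydroxymethyl at the same place gives a 4.0-fold higher number from compound 1 to compound 4 (0.60 log units; beyond the scatter), which shows that the shorter amide end, like the ureido end of compound 3, stays apart from the hydroxy end of compound 1, still the strongest inhibitor of growth among the four compounds. Carbamoylmethyl in place of 1-(hydroxymethyl)-2-methylpropyl on a sulfur gives a 5.1-fold lower number from compound 2 to compound 4 (0.71 log units; beyond the scatter), which puts compound 4 clearly on the stronger side of compound 2 even though compound 4 has no hydroxy group.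

No supporting data are available to account for any of these differences. Going by these compounds, it remains open whether the advantage of compound 1 is specific to the hydroxy group or would also appear with an amine or a carboxylic acid at the chain end, and whether a longer chain carrying the hydroxy group would keep it.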